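A few compounds are considered here, and "the series" means these few. Any claim that something is new, unique, unknown or untested is made for them only; others in the source may bear on it.

Compounds measured in a functional assay on CCRF-CEM cells (Homo sapiens) for antiproliferative activity, read by MTT assay, with a stated time of 24 h, tested at 100 uM; a lower number here means a stronger effect, a higher number a weaker effect of the compound at the concentration tested:
compound 1 `OCC(O)Cn1nc2c(Br)c(Br)c(Br)c(Br)c2n1` gives 8%;
compound 2 `OC(CCn1nc2c(Br)c(Br)c(Br)c(Br)c2n1)c1ccc(Br)cc1` gives 0%;
compound 3 `OC(CCn1nc2c(Br)c(Br)c(Br)c(Br)c2n1)c1ccccc1` gives 21%.

Among these three numbers compound 1 stands second highest. Its nearest neighbour is compound 2, whose number lies within the usual scatter of that of compound 1, so nothing can be said about an order between the two. Compound 3 lies furthest away, with a number beyond the scatter higher than that of compound 1.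

Compound 4 `C[C@@H](O)CCn1nc2c(Br)c(Br)c(Br)c(Br)c2n1` is not yet measured. It differs from compound 1 as follows: 2-hydroxypropyl in place of 1,2-dihydroxyethyl on a saturated chain carbon bound to an aromatic nitrogen.

Going by the values given here, the only step measured so far, a number 21 percentage points higher from compound 2 to compound 3 (beyond the scatter), concerns hydrogen in place of bromo on an aromatic carbon and leaves the chain on the aromatic nitrogen untouched, so it does not bear on the change from compound 1 to compound 4. Among the compounds with values here, no measured step touches that chain. With nothing to point either way, compound 4 is expected to stay close to compound 1, with a step of about a number 2 percentage points higher from compound 1 to compound 4 (within the scatter) in this assay, which is no step beyond the scatter. Compound 4 is therefore estimated at 10%, within a range from 0% to 30%.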

Compound 4, a percentage reported as activity, at one concentration (the size of the read-out at that concentration, not a potency): 36%
The estimate for compound 4 lay 26 percentage points below the measured number; the whole stated range lies below it.
By their numbers in this assay, from the lowest: compounds 2 and 1 (each within the scatter of the next); then compound 3; then compound 4.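

In this assay the chain on the aromatic nitrogen proves to be a place where the number can move: with 2-hydroxypropyl in place of 1,2-dihydroxyethyl, the result is a number 28 percentage points higher from compound 1 to compound 4 (beyond the scatter) and so a weaker effect at the concentration tested. Going by these compounds alone, until now the only measured step concerned a bromo on an aromatic carbon, so this is the first step to show that this position responds as well. Nothing at hand accounts for the step.

From the compounds shown here alone, the two chains differ at once in their hydroxyl count, their carbon count and the defined stereocentre, so it stays open which of these goes with the higher number. Also open, going by these compounds, is how an amine, a carboxylic acid or a longer chain at this position would read in this assay and how the opposite stereoisomer of compound 4 would compare.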